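Working notes: one methoxy removed from compound 2

This account rests on a few compounds, and the source may have more. Where it says the series, first, only, none or still open, it means among the compounds named here.

Measured in a functional assay on OVCAR-3 cells (Homo sapiens) for inhibition, read by sulforhodamine B assay, with a stated time of 48 h; a higher number here means that more compound is tolerated, a lower number that less compound is tolerated:
compound 1 `Nc1cc(N)c2nc(-c3ccccc3)c(Oc3ccc(Cl)c(Cl)c3)nc2c1` gives 66100 nM
compound 2 `COc1ccc(CNc2nc3cc(N)cc(N)c3nc2-c2ccccc2)cc1OC` gives 8510 nM
compound 3 `COc1cc(CNc2nc3cc(N)cc(N)c3nc2-c2ccccc2)cc(OC)c1OC` gives 18200 nM

Compound 2 has the lowest number of the three. Its nearest neighbour is reached by a 2.1-fold higher number from compound 2 to compound 3 (0.33 log units; beyond the scatter), a modest step; compound 1 lies much further off, with a markedly higher number.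

Compound 4 `COc1ccc(CNc2nc3cc(N)cc(N)c3nc2-c2ccccc2)cc1` differs from compound 2 by hydrogen in place of methoxy on an aromatic carbon. For the measured compounds named here, the only step that bears on this is a 2.1-fold higher number from compound 2 to compound 3 (0.33 log units; beyond the scatter), where a methoxy was added elsewhere on the same ring and the number rose modestly. Taking one away is expected to move the number by no more than that, in either direction, most likely within the scatter. Compound 4 is therefore estimated at 10000 nM, range 4000 nM to 25000 nM, meaning an expected 1.2-fold higher number from compound 2 to compound 4 (0.07 log units; within the scatter).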

Compound 4, concentration lethal to 50% of the cells: 38900 nM
Estimate against measurement, compound 4: 3.9-fold (0.59 log units) below; measured number outside the range, above it.
By their numbers in this assay, from the lowest: compound 2; then compound 3; then compounds 4 and 1 (each within the scatter of the next).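

In this assay, hydrogen in place of this methoxy gives a clear rise (a 4.6-fold higher number from compound 2 to compound 4 (0.66 log units; beyond the scatter)), so this position ortho to a methoxy group is sensitive to the change. Together with the earlier step (a 2.1-fold higher number from compound 2 to compound 3 (0.33 log units; beyond the scatter)), losing a methoxy here and adding one elsewhere on the ring both raise the number, and the 3,4-dimethoxyphenyl of compound 2 stays lowest among these three dimethoxy, trimethoxy and monomethoxy variants. No measurement at hand explains this.

On these data alone, whether a hydroxyl, an ethoxy or an amine at this position would keep or lower the number of compound 2 remains open.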